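Dimethoxyphenyl variant of a thiazolotriazine cell-growth series

The source may hold more compounds than are shown below. What is called first, only, known or untested is meant among the compounds shown, and "the series" means these compounds.

Measured so far:
compound 1 `C=C(Br)C(=O)Nc1cccc(-c2cn3nc(Cc4ccccc4)sc3n2)c1`: 3000 nM
compound 2 `C=C(Br)C(=O)Nc1cccc(-c2cn3nc(-c4ccccc4)sc3n2)c1`: 900 nM
compound 3 `COc1cccc(-c2nn3cc(-c4cccc(N)c4)nc3s2)c1`: 29000 nM

In a functional assay on FM3A cells (Mus musculus) for inhibition, read by cell counting, with a stated time of 2 days (a higher number here means a weaker inhibitor, a lower number a stronger inhibitor), compound 2 gives the lowest number of the three. Compound 1 stands nearest to it, and compound 3, which differs from compound 2 in more than one place, gives by far the highest number of the set. Among the measured compounds shown here, the only single-place step available is the one from compound 1 to compound 2, where exchanging benzyl for phenyl on an aromatic carbon of the shared core produced a 3.3-fold lower number from compound 1 to compound 2 (0.52 log units; beyond the scatter).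

Compound 4 `C=C(Br)C(=O)Nc1cccc(-c2cn3nc(-c4ccc(OC)c(OC)c4)sc3n2)c1` is not yet measured. Its change from compound 2 is 3,4-dimethoxyphenyl in place of phenyl on an aromatic carbon. This is the same position that was varied between compound 1 and compound 2, but the change here is an addition of two methoxy groups to the phenyl rather than a swap of the linking unit, so that earlier step gives only a loose guide. For the measured compounds named here, no measured pair shows what two methoxy groups do here. The step from compound 2 to compound 4 in this assay is therefore expected to be small: a 1.3-fold higher number from compound 2 to compound 4 (0.12 log units; within the scatter). Compound 4 is estimated at 1200 nM, with a range from 300 nM to 5000 nM.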

Compound 4, half-maximal inhibitory concentration: 110 nM
Compound 4: the middle estimate sits 11-fold (1.04 log units) above what was measured; measured number outside the range, below it.
By their numbers in this assay, from the lowest: compound 4; then compound 2; then compound 1; then compound 3.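

In this assay, the position on the five-membered aromatic ring does more than respond to the linking unit: substitution on the attached phenyl also moves the number, with 3,4-dimethoxyphenyl in place of phenyl giving an 8.2-fold lower number from compound 2 to compound 4 (0.91 log units; beyond the scatter) in the downward direction. The earlier compounds shown here showed only the effect of removing the benzyl linking carbon, whereas this result shows that the directly attached phenyl can carry two methoxy groups with no loss in this assay. Set against the benzyl group, the same 3,4-dimethoxyphenyl group gives a 27-fold lower number from compound 1 to compound 4 (1.44 log units; beyond the scatter) and so sets the widest span among the groups compared at this position, though no available evidence bears on the reason for these steps.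

Compound 3 carries a single methoxy group on its phenyl but also differs from compound 4 elsewhere, so the compounds shown do not settle whether one methoxy group would suffice or whether both contribute to the step. Also open, on these data alone, is whether a hydroxyl group, a carboxylic acid or a longer alkoxy chain on the phenyl would shift the number in this assay in the same direction.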